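The source may report more compounds than this note shows. Statements on the series, on what has been measured and on what is new or still open speak of the compounds shown alone.

Three compounds share one core and differ only at the far end of the chain. Compound 1 `CC(C)(C)OC(=O)N1CCC(CCCNc2ccc3c(c2)OCCS3(=O)=O)CC1` gives "not determined" (no result reported) in a functional assay on CHO-K1 cells for agonist activity at Glucose-dependent insulinotropic receptor (Mus musculus), read by HTRF and cAMP accumulation, with a stated time of 30 min (a lower number here means that less compound is needed, a higher number that more compound is needed for the effect), so no number stands for it there. Compound 2 `CC(C)(C)OC(=O)N1CCC(CCCNc2ccc3c(c2)OCC3=O)CC1` gives 66 nM in this assay, and compound 3 `CC(C)(C)OC(=O)N1CCC(CCCNc2ccc3c(c2)C(=O)NC3)CC1` gives 892 nM. Compound 2 stands at the lowest of the two numbers obtained, and its gap to compound 3 lies beyond the usual scatter of repeated measurements: compound 2 clearly needs less material for the same effect.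

Compound 4 `CCc1cnc(N2CCC(CCCNc3ccc4c(c3)OCC4=O)CC2)nc1` keeps the core of compound 2 and changes one thing: 5-ethylpyrimidin-2-yl in place of tert-butoxycarbonyl on an amine nitrogen in a ring. Going by the values given here, no measured pair differs only at this position, and nothing measured shows what such an exchange does. The expectation rests on the fact that the part of compound 2 that gave 66 nM is kept untouched, while a group of similar size takes the place of the one that leaves. A mild gain or a standstill seems the most likely outcome; a large loss would be a surprise. The step expected is a 2.2-fold lower number from compound 2 to compound 4 (0.34 log units; beyond the scatter), a shift that stays close to the scatter. Compound 4 is thus estimated at 30 nM, with a range from 8 nM to 120 nM.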

Compound 4, half-maximal effective concentration: 159 nM
Beside the measured number, compound 4's estimate is 5.3-fold (0.72 log units) below it; the measured number lies above the stated range.
By their numbers in this assay, from the lowest: compound 2; then compound 4; then compound 3.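

Compound 2 and compound 4 are the only pair shown that differs solely on the amine nitrogen in the six-membered ring, and in this assay the exchange of tert-butoxycarbonyl for 5-ethylpyrimidin-2-yl gives a 2.4-fold higher number from compound 2 to compound 4 (0.38 log units; beyond the scatter), a modest step. This shows that the group at this position does affect the number, but also that a group with no ring can give way to one with a six-membered aromatic ring and still leave a measurable response, even though the two groups have the same counts of hydrogen-bond donors and acceptors. No measurement at hand explains why the number moves in this direction.

The compounds shown leave open whether the step comes from the pyrimidine ring or from its ethyl group, which a pyrimidin-2-yl group without the ethyl, or one bearing a methyl or a propyl chain instead, could help to separate. They also leave open how other groups on this nitrogen, such as a pyridine ring or a simple acetyl group, would compare, and whether the same exchange would act alike on the core of compound 3.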